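The source may hold more compounds than are shown below. What is called first, only, known or untested is meant among the compounds shown, and "the series" means these compounds.

In a toxicity assay on MT4 cells (Homo sapiens) for cytotoxicity, read by MTT assay, with a stated time of 5 days (on this read-out lower numbers stand for higher toxicity in this test and higher numbers for lower toxicity in this test), compound 1 (`Cc1cc(-c2cc3ccccc3s2)cc(C)c1Nc1ccnc(Nc2ccc(C#N)cc2)n1`) gives 138000 nM, compound 2 (`Cc1cc(-c2cc(C)c(Nc3ccnc(Nc4ccc(C#N)cc4)n3)c(C)c2)cc(C)n1`) gives 2300 nM and compound 3 (`Cc1ncc(-c2cc(C)c(Nc3ccnc(Nc4ccc(C#N)cc4)n3)c(C)c2)cn1`) gives 3900 nM. Compound 3 therefore sits level with compound 2 within the scatter, and both lie far under compound 1. The next structure is compound 4 (`Cc1cc(-c2cnc(C(F)(F)F)nc2)cc(C)c1Nc1ccnc(Nc2ccc(C#N)cc2)n1`), not yet measured in this assay. It differs from compound 3 as follows: trifluoromethyl in place of methyl on an aromatic carbon. This is trifluoromethyl in place of methyl on an aromatic carbon, between two ring nitrogen atoms.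

Going by the values given here, no measured step makes this exchange, so the evidence is indirect. Two steps, a 60-fold lower number from compound 1 to compound 2 (1.78 log units; beyond the scatter) and a 35-fold lower number from compound 1 to compound 3 (1.55 log units; beyond the scatter), are large, but both remove the whole 1-benzothiophen-2-yl group. The closest guide is a 1.7-fold higher number from compound 2 to compound 3 (0.23 log units; within the scatter), which replaces 2,6-dimethylpyridin-4-yl with 2-methylpyrimidin-5-yl and stays within the scatter. The change to compound 4 touches only one substituent on the 2-methylpyrimidin-5-yl group, so no step beyond the scatter is expected in this assay. The estimated step is a 1.3-fold higher number from compound 3 to compound 4 (0.11 log units; within the scatter). For compound 4 the expected value is 5000 nM, with an estimated range from 1500 nM to 25000 nM. Among the compounds with values here, the range is kept wide, as only three measured compounds support it.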

Compound 4, half-maximal cytotoxic concentration: 4900 nM
Estimate against measurement, compound 4: 1.0-fold (0.01 log units) above; measured number inside the range.
By their numbers in this assay, from the lowest: compounds 2, 3 and 4 (each within the scatter of the next, the first and the last beyond it); then compound 1.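

At the aromatic carbon between two ring nitrogen atoms, para to a large group, the series now has its first direct exchange: in this assay, trifluoromethyl in place of methyl gives a 1.3-fold higher number from compound 3 to compound 4 (0.10 log units; within the scatter) and so does not separate the two groups, although one heavy atom is replaced by four. All earlier steps swapped a whole group on the aromatic carbon, so they could not show that this single substituent can change without a step beyond the scatter. Against the other whole groups, 2-(trifluoromethyl)pyrimidin-5-yl gives a 2.1-fold higher number from compound 2 to compound 4 (0.33 log units; beyond the scatter) as a modest step beyond the scatter, even though the step with 2-methylpyrimidin-5-yl in the same comparison stays within it, and a 28-fold lower number from compound 1 to compound 4 (1.45 log units; beyond the scatter) keeps the large gap seen with the other two groups.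

The compounds shown hold only methyl and trifluoromethyl at this position, so what an amine, a carboxylic acid or a longer chain there would do to the number stays open. No supporting measurement is available to explain the result.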